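The source may hold more compounds than are shown below. What is called first, only, known or untested is meant among the compounds shown, and "the series" means these compounds.

Measured compounds:
Compound 1 `Cc1ccc(OCC(=O)N(Cc2cccs2)c2nccs2)cc1` gives 2240 nM in an assay on HEK293 cells for agonist activity at transient receptor potential cation channel subfamily M member 8 (Homo sapiens), read by fluorescence and calcium flux, with a stated time of 15 min; a lower number here means that less compound is needed, a higher number that more compound is needed for the effect.
Compound 2 `Cc1ccc(/C=C/C(=O)N(Cc2cccs2)c2ccn[nH]2)cc1` gives 0.004 nM in this assay.
Compound 3 `Cc1ccc(OC2CCN(Cc3cccs3)C2=O)cc1` is reported as "not active" (no number reported) in this assay, without a number.

Of the two compounds with numbers, compound 1 stands at the higher end; compound 2 lies far below it, a gap well beyond the usual scatter. Among the measured compounds shown here, compound 4 `Cc1ccc(OCC(=O)N(Cc2cccs2)c2ccon2)cc1` keeps the core of compound 1 and changes only one ring: 1,2-oxazol-3-yl in place of 1,3-thiazol-2-yl on an amide-type nitrogen. For the measured compounds named here, with no measured pair sharing this change, the step from compound 1 to compound 4 is expected to be small, at most modest and in the direction of a higher number, a 1.4-fold higher number from compound 1 to compound 4 (0.15 log units; within the scatter). Compound 4 is therefore expected to give about 3200 nM, within 800 nM to 13000 nM.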

Compound 4, half-maximal effective concentration: 2 nM
Estimate against measurement, compound 4: 1600-fold (3.20 log units) above; measured number outside the range, below it.
By their numbers in this assay, from the lowest: compound 2; then compound 4; then compound 1.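

In this assay, the ring on the amide-type nitrogen turns out to matter greatly: 1,2-oxazol-3-yl in place of 1,3-thiazol-2-yl brings a 1100-fold lower number from compound 1 to compound 4 (3.05 log units; beyond the scatter) on its own. The two rings have the same count of heavy atoms, hydrogen-bond donors and acceptors, and neither carries a net charge, so those counts do not separate them. No measurement at hand accounts for the size of this step.

The compounds shown rest on this single exchange at this position, so it remains open how a phenyl ring there would compare. Also open, from the compounds shown here alone, is how an amine or a carboxylic acid on the 1,2-oxazol-3-yl ring would read.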